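The source may report more compounds than this note shows. Statements on the series, on what has been measured and on what is new or still open speak of the compounds shown alone.

Measured so far:
- compound 1 `Cc1ccc2ncc(S(=O)(=O)c3ccc(C)c(Cl)c3)c(N3CCC(C)CC3)c2c1` — 91%
- compound 2 `CC1CCN(c2c(S(=O)(=O)c3ccccc3)cnc3ccc(F)cc23)CC1` — 40%

In an assay on isolated protein for displacement of a labelled ligand from metabotropic glutamate receptor 5 (Homo sapiens), with a stated time of 60 min, tested at 1 uM (on this read-out lower numbers stand for less inhibition and higher numbers for more inhibition at the one concentration tested (going by the name of the read-out)), compound 2 gives 40%, the lower of the two numbers; compound 1 gives 91%, a gap that lies beyond the scatter. Compound 3 `Cc1ccc(S(=O)(=O)c2cnc3ccc(F)cc3c2N2CCC(C)CC2)cc1Cl` is not yet measured. It differs from compound 2 in one place: 3-chloro-4-methylphenyl in place of phenyl on a sulfonyl sulfur. Going by the values given here, compound 1, which carries the same 3-chloro-4-methylphenyl on its sulfonyl sulfur, gives the higher number in this assay, so a clear rise is expected, though with uncertainty since no single-change step is known. Compound 3 is expected to give 78% in this assay, between 55% and 95%, an estimated step of a number 38 percentage points higher from compound 2 to compound 3 (beyond the scatter).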

Compound 3, a percentage reported as inhibition, at one concentration (the size of the read-out at that concentration, not a potency): 91%
Estimate against measurement, compound 3: 13 percentage points below; the range from low to high includes it.
By their numbers in this assay, from the lowest: compound 2; then compounds 1 and 3 (each within the scatter of the next).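

In this assay, going by these compounds alone, 3-chloro-4-methylphenyl in place of phenyl on a sulfonyl sulfur gives a number 51 percentage points higher from compound 2 to compound 3 (beyond the scatter), so the gap between the earlier compounds can now be tied to this one place as a single measured step. With that group kept, fluoro in place of methyl on an aromatic carbon gives no change at the digits printed from compound 1 to compound 3 (within the scatter). Nothing at hand bears on the cause of the large step.

The compounds shown leave open whether 3-chlorophenyl or 4-methylphenyl alone would carry the step. They also leave open what a carboxylic acid or an amine on that phenyl ring would give.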